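This account rests on a few compounds, and the source may have more. Where it says the series, first, only, none or still open, it means among the compounds named here.

Compound 1 `COc1ccc(S(=O)(=O)N2CCc3cccc(-c4ccc([N+](=O)[O-])cc4)c32)cc1`: 53.1 nM
Compound 2 `COc1ccc(S(=O)(=O)N2CCc3cccc(-c4c(F)c(F)c(F)c(F)c4F)c32)cc1`: 4760 nM

Both values come from a functional assay on NCI-H460 cells (Homo sapiens) for inhibition, with a stated time of 72 h (a higher number here means a weaker inhibitor, a lower number a stronger inhibitor), and lie far apart, beyond the usual scatter. Compound 1 holds the lower of the two numbers, which makes it the stronger inhibitor of this pair. Compound 2 differs from it in the aryl group, and its number stands well above.

Compound 3 `COc1ccc(S(=O)(=O)N2CCc3cccc(-c4ccccc4)c32)cc1` has not yet been measured. Against compound 1 it shows a single change hydrogen in place of nitro on an aromatic carbon, para to a large group, which reads as 4-nitrophenyl to phenyl. For the measured compounds named here, no measured pair isolates this change, so its size can only be judged loosely. Going by the values given here, with compound 1 at 53.1 nM and compound 2 at 4760 nM as the only guides, a moderate rise toward weaker inhibition is expected, somewhat beyond the scatter. The estimated move is a 3.8-fold higher number from compound 1 to compound 3 (0.58 log units; beyond the scatter) and would leave the number well short of the high end seen so far. Compound 3 is expected at 200 nM (estimated range 50 nM to 1000 nM).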

Compound 3, half-maximal inhibitory concentration: 213 nM
Beside the measured number, compound 3's estimate is 1.1-fold (0.03 log units) below it; measured number inside the range.
By their numbers in this assay, from the lowest: compound 1; then compound 3; then compound 2.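

In this assay, for the compounds shown here, replacing the nitro group with hydrogen gives a 4.0-fold higher number from compound 1 to compound 3 (0.60 log units; beyond the scatter), the first step that isolates a single change at this place on the aromatic ring. The step lies beyond the scatter but remains modest, so the nitro group is not required for inhibition in the nanomolar range: compound 3, which carries a plain phenyl group, still gives 213 nM. No measurement bearing on the origin of this step is available, so the data record its size and direction but do not explain it.

This single pair cannot show how other groups on the same aromatic carbon would compare, such as an amine, a nitrile, a methoxy group or a carboxylic acid, or whether any of them would match or improve on the 4-nitrophenyl group of compound 1. It also leaves open whether a nitro group on another carbon of that ring would give a step of similar size.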